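Carbamate Alkyl Rearranged: From Branched to Linear-Branched Chain

The source may hold more compounds than are shown below. What is called first, only, known or untested is meant among the compounds shown, and "the series" means these compounds.

Compound 3, `COc1cc(C(=O)N2CCN(C(=O)c3cc(OC)c(OC)c(OC)c3)C(COC(=O)NC(C)C(C)C)C2)cc(OC)c1OC`, gives 80 nM in a functional assay (Oryctolagus cuniculus) for inhibition of platelet-activating factor receptor (Cavia porcellus) (on this read-out lower numbers stand for stronger inhibition and higher numbers for weaker inhibition), the lowest of the three numbers reported: compound 2, `CCCC(C)NC(=O)OCC1CN(C(=O)c2cc(OC)c(OC)c(OC)c2)CCN1C(=O)c1cc(OC)c(OC)c(OC)c1`, sits closest at 100 nM, a gap within the scatter, while compound 1, `CCCC(=O)OCC1CN(C(=O)c2cc(OC)c(OC)c(OC)c2)CCN1C(=O)c1cc(OC)c(OC)c(OC)c1`, lies furthest at 420 nM. Both carbamates improve on the ester of compound 1, as shown by a 4.2-fold lower number from compound 1 to compound 2 (0.62 log units; beyond the scatter) and a 5.3-fold lower number from compound 1 to compound 3 (0.72 log units; beyond the scatter). Within the carbamate pair, however, a 1.3-fold lower number from compound 2 to compound 3 (0.10 log units; within the scatter) stays within the scatter.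

Compound 4, `CCC(C)CNC(=O)OCC1CN(C(=O)c2cc(OC)c(OC)c(OC)c2)CCN1C(=O)c1cc(OC)c(OC)c(OC)c1`, differs from compound 3 by 2-methylbutyl in place of 1,2-dimethylpropyl on an amide-type nitrogen. For the measured compounds named here, only the step from compound 2 to compound 3 bears directly on this kind of reshaping of the carbamate alkyl chain, and that step was too small to count. Going by the values given here, the change here is of the same type, with the same atoms joined differently, and nothing among the measured compounds points to a direction. Compound 4 is therefore expected to show a 1.3-fold higher number from compound 3 to compound 4 (0.10 log units; within the scatter), a step within the scatter, in this assay. The estimated value of compound 4 is 100 nM, expected to fall between 45 nM and 220 nM.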

Compound 4, half-maximal inhibitory concentration: 470 nM
Compound 4: middle estimate off by 4.7-fold (0.67 log units), on the low side, outside the stated range (above it).
By their numbers in this assay, from the lowest: compounds 3 and 2 (each within the scatter of the next); then compounds 1 and 4 (each within the scatter of the next).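

In this assay the arrangement of the same carbon atoms on the amide-type nitrogen proves to matter: 2-methylbutyl in place of 1,2-dimethylpropyl gives a 5.9-fold higher number from compound 3 to compound 4 (0.77 log units; beyond the scatter), and 2-methylbutyl in place of 1-methylbutyl gives a 4.7-fold higher number from compound 2 to compound 4 (0.67 log units; beyond the scatter), although the step between the two earlier chains stayed within the scatter. The gain of the carbamates over the ester therefore does not hold for every chain of this size, since a 1.1-fold higher number from compound 1 to compound 4 (0.05 log units; within the scatter) leaves the 2-methylbutyl carbamate level with the propyl ester. Nothing available accounts for this difference between the chains.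

The compounds shown leave open how unbranched pentyl or cyclopentyl on the same nitrogen would compare. They also leave open whether a longer chain carrying 1-methyl branching would keep the lower numbers.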